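The compounds below may be only part of what the source reports. "The series", "measured", "known", "first", "only" and "open" are said of these compounds alone.

Measured compounds:
- compound 1, `COCC(C)(C)C#Cc1c(Cl)c2c(Cl)cc(C(N)=O)nc2n1[C@H]1CCCNC1`: 219 nM
- compound 2, `NC(=O)c1cc(Cl)c2c(Cl)c(C#CC3CCOCC3)n([C@H]3CCCNC3)c2n1`: 69 nM
- compound 3, `CN1CC(C#Cc2c(Cl)c3c(Cl)cc(C(N)=O)nc3n2[C@H]2CCCNC2)CC1=O`: 155 nM

In a functional assay on KG-1 cells (Homo sapiens) for antiproliferative activity (a higher number here means that more compound is needed for the effect, a lower number that less compound is needed), compound 3 stands second highest of the three numbers, within the scatter of compound 1 and set apart from compound 2 only by the step of a 2.2-fold higher number from compound 2 to compound 3 (0.35 log units; beyond the scatter). Compound 4, `COCCC#Cc1c(Cl)c2c(Cl)cc(C(N)=O)nc2n1[C@H]1CCCNC1`, carries the change (2-methoxyethyl in place of 1-methyl-5-oxopyrrolidin-3-yl on a triple-bonded carbon). Among the measured compounds shown here, the closest precedent is the reverse swap of an acyclic ether for the lactam, a 1.4-fold lower number from compound 1 to compound 3 (0.15 log units; within the scatter), which stayed within the scatter; the other ether step, a 3.2-fold lower number from compound 1 to compound 2 (0.50 log units; beyond the scatter), was modest and involved a ring. Compound 4 is therefore expected to sit near compound 3, with a 1.1-fold higher number from compound 3 to compound 4 (0.04 log units; within the scatter) and no clear step beyond the scatter. The estimate for compound 4 is 170 nM, ranging from 70 nM to 400 nM.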

Compound 4, half-maximal effective concentration: 39 nM
Beside the measured number, compound 4's estimate is 4.4-fold (0.64 log units) above it, outside the stated range (below it).
By their numbers in this assay, from the lowest: compounds 4 and 2 (each within the scatter of the next); then compounds 3 and 1 (each within the scatter of the next).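

In this assay, among the compounds shown here, the group on the triple-bonded carbon moves the number further than the earlier compounds showed, with 2-methoxyethyl giving a 5.6-fold lower number from compound 1 to compound 4 (0.75 log units; beyond the scatter) against one open-chain ether and a 4.0-fold lower number from compound 3 to compound 4 (0.60 log units; beyond the scatter) against the lactam, so open-chain ethers do not behave alike here. A ring does not settle the matter either, since oxan-4-yl stays level with the open chain (a 1.8-fold lower number from compound 2 to compound 4 (0.25 log units; within the scatter)) while 1-methyl-5-oxopyrrolidin-3-yl does not. Nothing measured here explains these differences.

As far as these compounds go, it remains open whether the ether oxygen of 2-methoxyethyl matters, which a plain butyl chain would test. An amine, a carboxylic acid or a longer ether chain at this place also remains unexplored in the compounds shown.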